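Furan-3-yl for sulfamoylphenyl on a shared aryl-acid core

The compounds below may be only part of what the source reports. "The series", "measured", "known", "first", "only" and "open" are said of these compounds alone.

Compound 1: `NS(=O)(=O)c1ccc(-c2nc(C(c3ccc(F)cc3)c3ccc(F)cc3)sc2CC(=O)O)cc1` — 80%
Compound 2: `O=C(O)Cc1sc(CS(=O)(=O)c2ccc(Cl)cc2)nc1-c1ccc(Cl)cc1` — 30%

Of the compounds shown here, two have been measured in an in vitro functional assay on HEK285-7 cells for antagonist activity at prostaglandin D2 receptor 2 (Homo sapiens), read by BRET and beta-arrestin recruitment; a higher number here means a larger maximal response, a lower number a smaller maximal response. Compound 1 gives 80%, and compound 2 gives 30%. Compound 1 therefore stands highest of the two, with compound 2 lying lower by a gap beyond the usual scatter. The two differ in several places at once, so no single structural change can be tied to that gap.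

Compound 3, `O=C(O)Cc1sc(C(c2ccc(F)cc2)c2ccc(F)cc2)nc1-c1ccoc1`, has not been measured. It differs from compound 1 in one place: furan-3-yl in place of 4-sulfamoylphenyl on an aromatic carbon. The group that leaves carries one hydrogen-bond donor and two acceptors, the group that enters carries none and one. Within the data shown here, with no measured pair that isolates this exchange, the account rests on compound 1 alone.

A moderate downward step a number 25 percentage points lower from compound 1 to compound 3 (beyond the scatter) is expected, since compound 1 gives 80% and the change removes the sulfamoyl group. Compound 3 is estimated at 55%, within 25% to 85%.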

Compound 3, largest response reached (reported as efficacy), in percent of the reference or control that the assay uses: 80%
Compound 3: the middle estimate sits 25 percentage points below what was measured; the measured number falls inside the stated range.
By their numbers in this assay, from the lowest: compound 2; then compounds 1 and 3 (each within the scatter of the next).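

In this assay, furan-3-yl in place of 4-sulfamoylphenyl gives no change at the digits printed from compound 1 to compound 3 (within the scatter), so this exchange on the aromatic carbon next to the ring nitrogen leaves the maximal response unmoved. On this core, then, neither the sulfamoyl group nor the six-membered aromatic ring is needed to reach that response, at least when furan-3-yl takes their place. Nothing measured here explains why the response holds across this exchange.

The compounds shown leave open how a phenyl without the sulfamoyl group would behave at this position, and with it whether an amine or a carboxylic acid on that ring would shift the response. Also open, as far as these compounds go, is which of the several differences of compound 2 goes with its 30%.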